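A Methoxy Added to a Weakly Active Amine

A few compounds are considered here, and "the series" means these few. Any claim that something is new, unique, unknown or untested is made for them only; others in the source may bear on it.

Compound 1, `COc1cc(NCc2ccccc2)cc(OC)c1OC`, gives > 80000 nM in a functional assay on KYSE-450 cells (Homo sapiens) for inhibition, read by MTT assay, with a stated time of 48 h (on this read-out higher numbers stand for weaker inhibition and lower numbers for stronger inhibition), which is a limit and not a number.
Compound 2, `C/C=C/C=C/C(=O)N(Cc1ccc(OC)c(O)c1)c1cc(OC)c(OC)c(OC)c1`, gives 180 nM in this assay.

Compound 1 thus sits at the limit of > 80000 nM in this assay, at which 1 of the 2 values shown sits; no single step connects it to compound 2, so the two values are only shown side by side. Compound 3, `COc1ccc(CNc2cc(OC)c(OC)c(OC)c2)cc1`, differs from compound 1 by methoxy in place of hydrogen on an aromatic carbon. No measured step sizes this change, and in this assay the step that the limit leaves unreadable from compound 1 to compound 3 is expected to be none beyond the scatter. Compound 3 is therefore estimated at 100000 nM, with a range from 30000 nM to 300000 nM.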

Compound 3, half-maximal inhibitory concentration: 4890 nM
Compound 3: middle estimate off by 20-fold (1.31 log units), on the high side, outside the stated range (below it).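

Placing methoxy in place of hydrogen on the aromatic carbon para to a large group gives, in this assay, an at least 16-fold lower number from compound 1 to compound 3 (1.21 log units; beyond the scatter). This position therefore responds strongly to one small group, and the change turns a compound without a readable number into one with a real value. The true size of the step stays unknown, as compound 1 rests on a limit: the limit of > 80000 nM in this assay, at which 1 of the 3 values shown sits.

On these data alone, whether the gain belongs to methoxy itself remains open. Ethoxy, a chlorine atom or an amine at this same place could give a smaller, similar or larger step.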